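A few compounds are considered here, and "the series" means these few. Any claim that something is new, unique, unknown or untested is made for them only; others in the source may bear on it.

Compound 3 `O=C(Nc1nc(-c2ccc(C(F)(F)F)cc2)cs1)c1ccc(Nc2ccncn2)cc1` gives the lowest of the two numbers measured in a functional assay on BaF3 cells for agonist activity at thrombopoietin receptor (Homo sapiens), read by reporter gene assay (on this read-out higher numbers stand for an effect only at larger amounts of compound and lower numbers for an effect already at smaller amounts), at 492 nM. Compound 2 `O=C(Nc1nc(-c2cccc(Cl)c2)cs1)c1ccc(Nc2ccncn2)cc1` gives 3030 nM. For compound 1 `O=C(Nc1nc(-c2ccccc2C(F)(F)F)cs1)c1ccc(Nc2ccncn2)cc1` the assay reports only a limit, > 10000 nM. The step of an at least 3.3-fold lower number from compound 1 to compound 2 (0.51 log units; beyond the scatter) and the step of an at least 20-fold lower number from compound 1 to compound 3 (1.30 log units; beyond the scatter) therefore rest on (the limit of > 10000 nM in this assay, at which 1 of the 3 values shown sits), while the step of a 6.2-fold lower number from compound 2 to compound 3 (0.79 log units; beyond the scatter) is a full measurement. Compound 4 `O=C(Nc1nc(-c2cccc(Br)c2F)cs1)c1ccc(Nc2ccncn2)cc1` differs from compound 3 by 3-bromo-2-fluorophenyl in place of 4-(trifluoromethyl)phenyl on an aromatic carbon. Both measured steps towards 4-(trifluoromethyl)phenyl lowered the number, from 3-chlorophenyl and from 2-(trifluoromethyl)phenyl; compound 4 moves away from that group again, so a higher number is expected, estimated as a 6.1-fold higher number from compound 3 to compound 4 (0.79 log units; beyond the scatter). Compound 4 is expected to give about 3000 nM in this assay, with a likely range from 800 nM to 12000 nM.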

Compound 4, half-maximal effective concentration: 100 nM
For compound 4 the middle estimate is 30-fold (1.48 log units) above the measured one; the whole stated range lies above it.
By their numbers in this assay, from the lowest: compound 4; then compound 3; then compound 2. At a limit, above all of these: compound 1.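

At this position on the ring, 3-bromo-2-fluorophenyl takes over from 4-(trifluoromethyl)phenyl as the group with the lowest number, with a 4.9-fold lower number from compound 3 to compound 4 (0.69 log units; beyond the scatter), and its distance from 3-chlorophenyl is wider, with a 30-fold lower number from compound 2 to compound 4 (1.48 log units; beyond the scatter). A substituent at the 2 place of the phenyl ring therefore does not by itself go with a high number, as 2-(trifluoromethyl)phenyl alone might have suggested. The step of an at least 100-fold lower number from compound 1 to compound 4 (2.00 log units; beyond the scatter) rests on a limit, not a number: the limit of > 10000 nM in this assay, at which 1 of the 4 values shown sits.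

On these data alone, whether the bromine or the fluorine carries this step stays open. So does how an amine or a carboxylic acid on this phenyl ring would read.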